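The source may report more compounds than this note shows. Statements on the series, on what has been measured and on what is new or still open speak of the compounds shown alone.

Measured compounds:
- compound 1, `COc1ccc(-c2noc(-c3ccc(F)cc3)n2)cc1O`: > 1000000 nM
- compound 2, `COc1cc(-c2noc(-c3ccncc3)n2)ccc1OCc1ccccc1`: > 1000000 nM
- compound 3, `COc1ccc(-c2noc(-c3cccnc3)n2)cc1OC1CCCC1`: > 1000000 nM

In a functional assay on PC-3 cells (Homo sapiens) for antiproliferative activity, read by MTT assay, with a stated time of 24 h (on this read-out higher numbers stand for weaker inhibition and lower numbers for stronger inhibition), compound 1 gives > 1000000 nM, which is a limit of the assay rather than a number. Compound 2 likewise reaches only a limit in this assay, > 1000000 nM. Compound 3, the starting point here, is also reported only as a limit in this assay, > 1000000 nM. Compound 3 therefore stands nowhere in particular among the three: all of them sit together at the limit of > 1000000 nM in this assay, at which 3 of the 3 values shown sit, and no order among them can be read.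

Compound 4, `COc1ccc(-c2noc(-c3ccc(O)cc3)n2)cc1OC1CCCC1`, differs from compound 3 in one place: 4-hydroxyphenyl in place of pyridin-3-yl on an aromatic carbon. Among the compounds with values here, no measured pair in this set shows what such a change does, so nothing in these data points toward a step in either direction; the expectation is one of no change beyond the usual scatter. Compound 4 is therefore expected to give 2000000 nM in this assay, with a range from 500000 nM to 10000000 nM. The step that this estimate implies, a step that the limit leaves unreadable from compound 3 to compound 4, is itself only an expectation, and it is more likely that compound 4 too returns only a limit.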

Compound 4, half-maximal inhibitory concentration: 162000 nM
For compound 4 the middle estimate is 12-fold (1.09 log units) above the measured one; the measured number lies below the stated range.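

In this assay, 4-hydroxyphenyl in place of pyridin-3-yl on an aromatic carbon of the five-membered aromatic ring gives an at least 6.1-fold lower number from compound 3 to compound 4 (0.79 log units; beyond the scatter). Within the data shown here, this is the first readable sign that a change at this position can move the read-out at all, as compound 4 alone comes away from the value shared by the others: the limit of > 1000000 nM in this assay, at which 3 of the 4 values shown sit. The change brings in a ring of carbon only and a hydrogen-bond donor together, and the step has only a lower bound, as the value of compound 3 is a limit and not a number.

The compounds shown do not separate the loss of the ring nitrogen from the arrival of the hydroxyl, so it stays open whether a plain phenyl at this position would produce a similar step. As far as these compounds go, it also stays open whether the hydroxyl itself can be exchanged, for instance for a methoxy group, an amine or a carboxylic acid at the same place on the phenyl ring, and how far such groups would carry the read-out from that of compound 4.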